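This account rests on a few compounds, and the source may have more. Where it says the series, first, only, none or still open, it means among the compounds named here.

Three compounds that share one core have been run in a functional assay on the whole organism for inhibition, with Rattus norvegicus as the target, read by paw edema, at a dose of 100 mg/kg by the oral route; on this read-out higher numbers stand for more inhibition at the one dose given (going by the name of the read-out) and lower numbers for less inhibition. Compound 1 `CCOC(=O)c1c(O)c2cccnc2n(-c2ccccc2)c1=O` gives 23.5%. Compound 2 `COc1ccc(NC(=O)c2c(O)c3cccnc3n(-c3ccccc3)c2=O)cc1` gives 0.3%, and compound 3 `Cc1ccccc1NC(=O)c1c(O)c2cccnc2n(-c2ccccc2)c1=O` gives 11.7%. Compound 3 therefore sits second of the three: the step of a number 11.4 percentage points higher from compound 2 to compound 3 (beyond the scatter) separates it from its nearest neighbour, while the step of a number 11.8 percentage points lower from compound 1 to compound 3 (beyond the scatter) separates it from compound 1, the highest of the set.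

Compound 4 `O=C(NCc1cccnc1)c1c(O)c2cccnc2n(-c2ccccc2)c1=O` is the next to be measured. Its change from compound 3 is (pyridin-3-yl)methyl in place of 2-methylphenyl on an amide-type nitrogen, so the ring of carbon only on the amide-type nitrogen gives way to a six-membered aromatic ring with 1 hetero atom carrying one hydrogen-bond acceptor. Among the measured compounds shown here, the steps that bear on this are the amide swaps: a number 23.2 percentage points lower from compound 1 to compound 2 (beyond the scatter) and a number 11.8 percentage points lower from compound 1 to compound 3 (beyond the scatter) place both amides under the ester, and a number 11.4 percentage points higher from compound 2 to compound 3 (beyond the scatter) shows that exchanging one group on the amide-type nitrogen for another moves the read-out by a modest amount. A modest shift in this assay, in either direction, is thus expected for compound 4. Compound 4 is estimated at 8%, between 0% and 22%, an expected step of a number 3.7 percentage points lower from compound 3 to compound 4 (within the scatter).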

Compound 4, a percentage reported as inhibition, in the whole organism at one dose (the size of the read-out at that dose, not a potency): 25.5%
For compound 4 the middle estimate is 17.5 percentage points below the measured one, and the stated range ends below it.
By their numbers in this assay, from the lowest: compound 2; then compound 3; then compounds 1 and 4 (each within the scatter of the next).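

In this assay, among the compounds shown here, the group on the amide-type nitrogen matters more than the earlier compounds showed: (pyridin-3-yl)methyl gives a number 13.8 percentage points higher from compound 3 to compound 4 (beyond the scatter) and a number 25.2 percentage points higher from compound 2 to compound 4 (beyond the scatter) as its two comparisons with the other amides. Both earlier amides lay under the ester, yet a number 2 percentage points higher from compound 1 to compound 4 (within the scatter) shows that this amide cannot be told apart from the ester, so swapping ethoxy for an amine-linked group does not by itself lower the read-out. Nothing measured here explains why this group behaves differently.

The swap brings in a ring nitrogen and a methylene link together, and the compounds shown leave open which of the two goes with the higher number. A plain phenylmethyl group would separate them, while pyridin-4-ylmethyl or the longer 2-(pyridin-3-yl)ethyl would test the ring nitrogen's place and the chain length.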